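The source may report more compounds than this note shows. Statements on the series, on what has been measured and on what is new or still open speak of the compounds shown alone.

Working notes on the series. Compound 1 `CC(C)CCCCCCCCCCCCC(=O)N[C@@H]1[C@@H](O)[C@H](O)[C@@H](Nc2ncnc3[nH]cnc23)O[C@H]1C` gives in a functional assay on L1210 cells (Mus musculus) for cytotoxicity (a higher number here means a weaker inhibitor, a lower number a stronger inhibitor), only a limit, > 100000 nM, (the limit of > 100000 nM in this assay, at which 1 of the 3 values shown sits). Compound 2 `CCCCCCCCCCCC(=O)NCC(=O)N[C@@H]1[C@@H](O)[C@H](O)[C@@H](Nc2ncnc3[nH]cnc23)O[C@H]1C` likewise gives in this assay a limit and not a number, > 10000 nM, (the limit of > 10000 nM in this assay, at which 1 of the 3 values shown sits). Compound 3 `CCOCCC(=O)NCC(=O)N[C@@H]1[C@@H](O)[C@H](O)[C@@H](Nc2ncnc3[nH]cnc23)O[C@H]1CO` reaches in this assay a limit as well, > 500000 nM, (the limit of > 500000 nM in this assay, at which 1 of the 3 values shown sits). Among the compounds with values here, compound 2 thus stands at a limit, as do the two other values shown, so no step between measured compounds can be counted and no ordering among them is read. Compound 4 `CCCCCCCCCCCC(=O)NCC(=O)N[C@@H]1[C@@H](O)[C@H](O)[C@@H](Nc2ncnc3[nH]cnc23)O[C@H]1CO` is not yet measured in this assay. It differs from compound 2 by hydroxy in place of hydrogen on a saturated chain carbon bound to a saturated ring carbon. Since all three measured values in this assay are limits, the step is expected to be none beyond the scatter, a step that the limit leaves unreadable from compound 2 to compound 4, with no direction to be read from the data. Compound 4 is therefore estimated at 30000 nM in this assay, within 10000 nM to 300000 nM, and most likely again reported only as a limit.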

Compound 4, half-maximal inhibitory concentration: 3000 nM
The estimate for compound 4 lay 10-fold (1.00 log units) above the measured number; measured number outside the range, below it.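

In this assay, hydroxy in place of hydrogen on a saturated chain carbon bound to a saturated ring carbon gives an at least 3.3-fold lower number from compound 2 to compound 4 (0.52 log units; beyond the scatter), so methyl to hydroxymethyl at this position matters when the nonyl-bearing chain is present. With the hydroxymethyl kept, nonyl in place of ethoxy gives an at least 160-fold lower number from compound 3 to compound 4 (2.22 log units; beyond the scatter), so the chain matters as well. Among the compounds shown, only compound 4 carries both features and gives a number, while compound 2, with the nonyl alone, and compound 3, with the hydroxymethyl alone, each remain a limit.

Both steps start from a limit, so their true sizes stay open, and no other step among these compounds can be read. Also open, from the compounds shown here alone, is whether an amine or a carboxylic acid in place of the hydroxy, or a longer chain in place of the nonyl, would keep or change the number of compound 4.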